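A few compounds are considered here, and "the series" means these few. Any claim that something is new, unique, unknown or untested is made for them only; others in the source may bear on it.

Compound 1 `O=Cc1ccc(-c2cn3ccnc3c(-c3ccc4ncn(C5CCCCC5)c4c3)n2)cc1`: 33.8%
Compound 2 `c1cn2cc(-c3ccc4c(c3)ncn4C3CCCCC3)nc(-c3ccc4ncn(C5CCCCC5)c4c3)c2n1`: 27.7%

In a functional assay on BT-549 cells (Homo sapiens) for inhibition, read by sulforhodamine B assay, with a stated time of 48 h, tested at 10 uM (on this read-out higher numbers stand for more inhibition at the one concentration tested (going by the name of the read-out) and lower numbers for less inhibition), compound 1 gives 33.8% and compound 2 gives 27.7%. Compound 2 has the lower of these two numbers, yet the gap to compound 1 lies within the usual scatter, so the two cannot be told apart. Compound 3 `c1ccc(Cn2cnc3ccc(-c4nc(-c5ccc6c(c5)ncn6C5CCCCC5)cn5ccnc45)cc32)cc1` differs from compound 2 in one place: benzyl in place of cyclohexyl on an aromatic nitrogen. For the measured compounds named here, no step between measured compounds shows what such a change does here, so only a small shift, if any, in either direction is expected. Compound 3 is expected to give about 27%, ranging from 12% to 45%. This estimate means a step of a number 0.7 percentage points lower from compound 2 to compound 3 (within the scatter), expected to stay inside the scatter.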

Compound 3, a percentage reported as inhibition, at one concentration (the size of the read-out at that concentration, not a potency) in the BT-549 assay: -44.7%
Estimate against measurement, compound 3: 71.7 percentage points above, and the stated range ends above it.
By their numbers in the BT-549 assay, from the lowest: compound 3; then compounds 2 and 1 (each within the scatter of the next).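

The group on this aromatic nitrogen matters greatly: in the BT-549 assay, benzyl in place of cyclohexyl gives a number 72.4 percentage points lower from compound 2 to compound 3 (beyond the scatter) and turns the positive reading of compound 2 (27.7%) into the negative reading of compound 3 (-44.7%). In a physicochemical assay for lipophilicity, using the shake flask method, in phosphate buffer, measured as octanol-water partition, with a stated time of 85 min, at pH 7.4 (on this read-out lower numbers stand for lower lipophilicity and higher numbers for higher lipophilicity), compound 2 gives 1.9 and compound 3 gives 1.61; the same change gives a number 0.29 log units lower from compound 2 to compound 3 (within the scatter), so this measurement does not separate the two compounds. No supporting evidence explains the large change in cell response.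

Still open, on these data alone, is whether a simple ethyl group or an amine-bearing chain on this nitrogen would preserve inhibition. It is also unclear whether changing the other cyclohexyl would have a similar effect.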